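The source may hold more compounds than are shown below. What is called first, only, known or untested is meant among the compounds shown, and "the series" means these compounds.

Compound 1 `Cc1ccc(-c2cc(Cl)cc(Nc3cc(C)nc(N)n3)c2)cc1` carries a 4-methylphenyl group on its core. In an assay on cells for inhibition of S-adenosylmethionine decarboxylase proenzyme (Homo sapiens), read by mass spectrometry, at pH 7.2 (a lower number here means a stronger inhibitor, a higher number a weaker inhibitor), compound 1 gives only a limit, > 63000 nM, not a number. Compound 2 `Cc1cc(Nc2cc(Cl)cc(-c3ccc(C(F)(F)F)cc3)c2)nc(N)n1` has a trifluoromethyl in place of methyl on an aromatic carbon. Compound 2 likewise gives only a limit, > 21000 nM. The step that the two limits leave unreadable from compound 1 to compound 2 cannot be read. Compound 1 sits at the limit of > 63000 nM in this assay, at which 1 of the 2 values shown sits. Compound 2 sits at the limit of > 21000 nM in this assay, at which 1 of the 2 values shown sits. Compound 3 `Cc1cc(Nc2cc(Cl)cc(-c3cncs3)c2)nc(N)n1` makes a different change: 1,3-thiazol-5-yl in place of 4-methylphenyl on an aromatic carbon. For the measured compounds named here, no measured step bears on this change, and nothing here shows a real inhibitor. Compound 3 is therefore expected to remain weak, an estimated 60000 nM (range 10000 nM to 300000 nM), meaning an expected step of an at least 1.0-fold lower number from compound 1 to compound 3 (0.02 log units; that floor lies within the scatter).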

Compound 3, half-maximal inhibitory concentration: > 21000 nM
Compound 3: no number, only a limit; the forecaster's own chance of this, stated with the estimate: 80%; the middle value is on the limit's open side.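

Compound 1 and compound 3 both give only limits in this assay, so the step between them cannot be read. The compounds shown leave open whether any group at this place on the shared core gives a measurable value.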